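The source may hold more compounds than are shown below. What is called first, only, known or untested is meant among the compounds shown, and "the series" means these compounds.

In an ADME assay on liver for metabolic stability, with Liver microsome (Homo sapiens) as the target, using microsomes and NADPH, with a stated time of 30 min, tested at 0.5 uM (a lower number here means slower removal, a higher number faster removal of the compound), compound 1 (`CC(Oc1nn(-c2ccccc2F)c2ccc(F)cc12)C(=O)N1CCOCC1`) gives 317 mL/min/kg and compound 2 (`O=C1OCCN1CCOc1nn(-c2ccccc2F)c2ccc(F)cc12`) gives 683 mL/min/kg, the higher of the two numbers and beyond the scatter of the other. Compound 3 (`O=C(COc1nn(-c2ccccc2F)c2ccc(F)cc12)N1CCOCC1`) departs from compound 2 by one change: (morpholin-4-yl)carbonyl in place of (2-oxo-1,3-oxazolidin-3-yl)methyl on a saturated chain carbon bound to an oxygen on an aromatic ring. Going by the values given here, no step between measured compounds is available as a guide. Compound 1, which also carries (morpholin-4-yl)carbonyl, stands at 317 mL/min/kg, so a fall beyond the scatter is expected in this assay. The estimated change is a 2.3-fold lower number from compound 2 to compound 3 (0.36 log units; beyond the scatter). Compound 3 is estimated at 300 mL/min/kg, with a range of 150 mL/min/kg to 600 mL/min/kg.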

Compound 3, clearance: 117 mL/min/kg
Estimate against measurement, compound 3: 2.6-fold (0.41 log units) above, outside the stated range (below it).
By their numbers in this assay, from the lowest: compound 3; then compound 1; then compound 2.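

In this assay the step from (2-oxo-1,3-oxazolidin-3-yl)methyl to (morpholin-4-yl)carbonyl on this saturated chain carbon is now read directly, as a 5.8-fold lower number from compound 2 to compound 3 (0.77 log units; beyond the scatter) on the unsubstituted chain. Hydrogen in place of methyl on the saturated chain carbon bound to a carbonyl carbon and an oxygen on an aromatic ring gives a 2.7-fold lower number from compound 1 to compound 3 (0.43 log units; beyond the scatter) in the same read-out, so the methyl of compound 1 goes with faster removal. No measurement shown gives a cause for either step.

Still open, going by these compounds, is how a longer chain carrying (morpholin-4-yl)carbonyl would compare with compound 3. An amine or a carboxylic acid in place of (morpholin-4-yl)carbonyl also remains to be placed against compound 3.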